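Methoxycarbonyl in place of hydrogen on compound 3

The source may report more compounds than this note shows. Statements on the series, on what has been measured and on what is new or still open speak of the compounds shown alone.

Compound 1 `CCc1ccc(-c2nc3c(c(C)nn3-c3ccccc3)c(-c3ccccc3[N+](=O)[O-])c2C#N)cc1`: 1200 nM
Compound 2 `CCc1ccc(-c2nc3c(c(C)nn3-c3ccccc3)c(-c3ccccc3C(F)(F)F)c2C#N)cc1`: 11000 nM
Compound 3 `CCc1ccc(-c2nc3c(c(C)nn3-c3ccccc3)c(-c3ccccc3)c2C#N)cc1`: 47000 nM

In a physicochemical assay for solubility, read by spectrophotometry, in phosphate buffer, with a stated time of 18 h, at pH 7.4 (a higher number here means a more soluble compound, a lower number a less soluble compound), compound 3 gives 47000 nM, the highest of the three numbers. Compound 4 `CCc1ccc(-c2nc3c(c(C)nn3-c3ccccc3)c(-c3ccccc3C(=O)OC)c2C#N)cc1` differs from it by methoxycarbonyl in place of hydrogen on an aromatic carbon, ortho to a large group. Among the compounds with values here, two measured steps bear on this change: a 4.3-fold higher number from compound 2 to compound 3 (0.63 log units; beyond the scatter) and a 39-fold higher number from compound 1 to compound 3 (1.59 log units; beyond the scatter). Both end at hydrogen, so the reverse change points to a lower number, of modest to large size. Within the data shown here, no measured compound carries methoxycarbonyl, so the range is kept wide. The expected step is a 5.9-fold lower number from compound 3 to compound 4 (0.77 log units; beyond the scatter). For compound 4 the estimated value is 8000 nM, with an expected range of 2000 nM to 30000 nM.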

Compound 4, solubility: 17000 nM
Compound 4: the middle estimate sits 2.1-fold (0.33 log units) below what was measured, and the stated range covers the measured number.
By their numbers in this assay, from the lowest: compound 1; then compounds 2 and 4 (each within the scatter of the next); then compound 3.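

In this assay methoxycarbonyl on this aromatic carbon gives a lower number than hydrogen (a 2.8-fold lower number from compound 3 to compound 4 (0.44 log units; beyond the scatter)), so hydrogen remains the highest of the four. Methoxycarbonyl cannot be separated from trifluoromethyl (a 1.5-fold higher number from compound 2 to compound 4 (0.19 log units; within the scatter)), while nitro stays clearly the lowest (a 14-fold higher number from compound 1 to compound 4 (1.15 log units; beyond the scatter)). No evidence at hand accounts for these differences.

Still open, as far as these compounds go, is whether a carboxylic acid or an amine on this aromatic carbon would end nearer hydrogen or nearer nitro. From the compounds shown here alone, all four compounds share the rest of the core, so whether these steps carry over to other cores is also open.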